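From an ethyl to a tert-butyl carbonyl on a ring nitrogen

The source may hold more compounds than are shown below. What is called first, only, known or untested is meant among the compounds shown, and "the series" means these compounds.

Measured so far:
Compound 1, `CNc1ncc2c(-c3ccc(N4CCN(C)CC4)nc3)nn(Cc3cn(Cc4ccccc4)nn3)c2n1`, gives in an assay on isolated protein for inhibition of RAC-alpha serine/threonine-protein kinase (Homo sapiens), read by 33P incorporation, in the presence of a further agent that is not named here (on this read-out higher numbers stand for weaker inhibition and lower numbers for stronger inhibition), only a limit of > 10000 nM.
Compound 2, `CCN1CCN(c2ccc(-c3nn(Cc4cn(Cc5ccccc5)nn4)c4nc(NC)ncc34)cn2)CC1`, gives in this assay 1900 nM.

Within the data shown here, compound 2 thus holds the only measured number here; the other value is a limit (the limit of > 10000 nM in this assay, at which 1 of the 2 values shown sits). Compound 3, `CNc1ncc2c(-c3ccc(N4CCN(C(=O)C(C)(C)C)CC4)nc3)nn(Cc3cn(Cc4ccccc4)nn3)c2n1`, differs from compound 2 by (tert-butyl)carbonyl in place of ethyl on an amine nitrogen in a ring. Among the measured compounds shown here, the one measured step at this ring nitrogen, an at least 5.2-fold lower number from compound 1 to compound 2 (0.72 log units; beyond the scatter), shows that a larger alkyl group on that nitrogen went with stronger inhibition, though it starts from a limit, so its true size is unknown. For the measured compounds named here, that step swaps one small alkyl for another; the change to compound 3 instead brings in a carbonyl group, for which no measured step exists. With so little to go on, the expected step of a 1.6-fold higher number from compound 2 to compound 3 (0.20 log units; within the scatter) is kept modest and the range wide. Compound 3 is estimated to give 3000 nM in this assay, between 800 nM and 12000 nM.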

Compound 3, half-maximal inhibitory concentration: > 10000 nM
Compound 3 ended at the assay's limit; the forecaster's own chance of this, stated with the estimate: 30%; at least 3.3-fold (0.52 log units) between middle value and limit.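

At the amine nitrogen in the ring, replacing ethyl with (tert-butyl)carbonyl in this assay gives an at least 5.2-fold higher number from compound 2 to compound 3 (0.72 log units; beyond the scatter), so inhibition at this position can be lost as well as gained. The stronger inhibition seen on going from methyl to ethyl therefore does not carry through to every larger group, and among these three compounds the number of heavy atoms on this nitrogen does not set the order. Compound 1 and compound 3 both stand at a limit, so the step between them cannot be read: the limit of > 10000 nM in this assay, at which 2 of the 3 values shown sit.

From the compounds shown here alone, the change to compound 3 brings in the carbonyl and the tert-butyl together, so their separate contributions remain unknown. An acetyl group would keep the carbonyl with a small end, and a propyl or isopropyl group would show how the alkyl series continues without a carbonyl.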